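Trimming the aryl group of a fatty acid amide hydrolase inhibitor

The source may report more compounds than this note shows. Statements on the series, on what has been measured and on what is new or still open speak of the compounds shown alone.

Compound 1, `NC(=O)c1ccc(-c2cnc(C(=O)CCCCCCc3ccccc3)o2)nc1`: 1.2 nM
Compound 2, `NS(=O)(=O)c1ccc(-c2cnc(C(=O)CCCCCCc3ccccc3)o2)s1`: 3 nM

Two compounds share a core and a long phenyl-capped chain and differ only in the aryl group attached to the core. Among the measured compounds shown here, in an assay (Rattus norvegicus) for inhibition of Fatty-acid amide hydrolase 1 (Homo sapiens) (a lower number here means a stronger inhibitor, a higher number a weaker inhibitor), compound 1 gives 1.2 nM and compound 2 gives 3 nM, so compound 2 holds the higher of the two numbers; the single measured step, a 2.5-fold higher number from compound 1 to compound 2 (0.40 log units; beyond the scatter), swaps one aryl group for another and moves the number only modestly.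

Compound 3, `CNC(=O)c1cnc(C(=O)CCCCCCc2ccccc2)o1`, goes further: methylcarbamoyl in place of 5-sulfamoylthiophen-2-yl on an aromatic carbon. For the measured compounds named here, the ring that was changed in the one known step is now removed altogether and replaced by a small amide. Going by the values given here, no measured step covers such a removal; the step from compound 1 to compound 2 only shows that exchanging one aryl group for another costs little in this assay. Taking away the ring is a larger change than that swap, so a weaker inhibitor is expected, and the estimate for the step from compound 2 to compound 3 is a 33-fold higher number from compound 2 to compound 3 (1.52 log units; beyond the scatter). Compound 3 is therefore expected to give about 100 nM in this assay, with a range from 15 nM to 800 nM.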

Compound 3, inhibition constant: 7 nM
Beside the measured number, compound 3's estimate is 14-fold (1.15 log units) above it; the whole stated range lies above it.
By their numbers in this assay, from the lowest: compound 1; then compound 2; then compound 3.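

In this assay an aromatic ring at this place, next to the ring oxygen, turns out not to be needed for a low number: with 5-sulfamoylthiophen-2-yl exchanged for the much smaller methylcarbamoyl, which has no ring, the result is a 2.3-fold higher number from compound 2 to compound 3 (0.37 log units; beyond the scatter) and remains a modest step. Against the other aryl group the result is a 5.8-fold higher number from compound 1 to compound 3 (0.77 log units; beyond the scatter) and is also modest, so both ring-bearing compounds give lower numbers than compound 3, but the ring is worth far less than its size might suggest. Nothing available here explains why so large a change in the group moves the number so little.

Still open, going by these compounds, is how much of the strength of compound 3 comes from methylcarbamoyl itself, and how much would remain with a bare hydrogen, a carboxylic acid or a methyl ester on the same carbon. The shared seven-carbon-long stretch of chain and its phenyl cap also stay fixed throughout, so a shorter chain might or might not be tolerated alongside this small amide.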